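The compounds below may be only part of what the source reports. "The series", "measured", "known", "first", "only" and "open" are said of these compounds alone.

Measured so far in an assay on cells for inhibition of HSP60/HSP10 (Homo sapiens), with a stated time of 60 min; on this read-out higher numbers stand for weaker inhibition and lower numbers for stronger inhibition:
compound 1, `O=S(=O)(Nc1ccc(-c2nc3ccccc3o2)cc1)c1cccc(Cl)c1`, gives 54000 nM.
compound 2, `Cc1cccc(S(=O)(=O)Nc2ccc(-c3nc4ccccc4o3)cc2)c1`, gives > 100000 nM, which is a limit of the assay.
compound 3, `O=S(=O)(Nc1ccc(-c2nc3ccccc3o2)cc1)c1ccccc1Cl`, gives > 100000 nM, which is a limit of the assay.

Compound 3 thus stands at the limit of > 100000 nM in this assay, at which 2 of the 3 values shown sit, so its place among the three is not a number but a limit. The step of an at least 1.8-fold higher number from compound 1 to compound 3 (0.26 log units; that floor lies within the scatter) ends at that same limit, and the step that the two limits leave unreadable from compound 2 to compound 3 runs between two limits. Compound 4, `O=S(=O)(Nc1ccc(-c2nc3ccccc3o2)cc1)c1ccccc1F`, differs from compound 3 by fluoro in place of chloro on an aromatic carbon. Within the data shown here, no measured step exchanges chloro for fluoro, so the pair compound 1 to compound 3 is the nearest evidence, and it fixes only a limit. The expected step that the limit leaves unreadable from compound 3 to compound 4 is therefore none beyond the scatter. For compound 4 the estimate in this assay is 150000 nM, ranging from 60000 nM to 400000 nM, most likely again reported only as a limit.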

Compound 4, half-maximal inhibitory concentration: > 100000 nM
Compound 4: no number, only a limit; the forecaster's own chance of this, stated with the estimate: 75%; the middle value is on the limit's open side.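

With fluoro in place of chloro on an aromatic carbon ortho to a large group, compound 4 in this assay gives > 100000 nM, which is a limit of the assay. Against compound 1, the only compound with a number, the reading is an at least 1.8-fold higher number from compound 1 to compound 4 (0.26 log units; that floor lies within the scatter). The steps to compound 4 from compound 2 and compound 3 cannot be read, and the ceiling now holds most of the set: the limit of > 100000 nM in this assay, at which 3 of the 4 values shown sit.

As far as these compounds go, whether fluoro and chloro differ at this place stays open. Also open, from the compounds shown here alone, is whether an amine or a carboxylic acid in place of the halogen would give a number rather than a limit.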